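A few compounds are considered here, and "the series" means these few. Any claim that something is new, unique, unknown or untested is made for them only; others in the source may bear on it.

Working notes on the series.

Compound 1 `CC(=O)N[C@@H]1CCC[C@H](C(=O)Nc2cc(-c3cnn4c3CCCC4)c(F)cn2)C1` carries a fluoro group on the pyridine-type ring; compound 2 `CC(=O)N[C@@H]1CCC[C@H](C(=O)Nc2cc(-c3cnn4c3CCCC4)c(Cl)cn2)C1` differs by chloro in place of fluoro on an aromatic carbon. In a physicochemical assay for solubility, in phosphate buffer, at pH 7.4 (on this read-out lower numbers stand for lower solubility and higher numbers for higher solubility), compound 1 gives > 1000000 nM, which is a limit of the assay and not a number (the limit of > 1000000 nM in this assay, at which 1 of the 3 values shown sits). In this assay compound 2 gives 310000 nM, so the step of an at least 3.2-fold lower number from compound 1 to compound 2 (0.50 log units; beyond the scatter).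

Compound 3 `CC(=O)N[C@@H]1CCC[C@H](C(=O)Nc2cc(-c3cnn4c3CC(C)(C)C4)c(F)cn2)C1` keeps the fluoro group but changes the core: a group of 10 heavy atoms (8 carbon, 2 nitrogen; one five-membered non-aromatic ring with 1 hetero atom, one five-membered aromatic ring with 2 hetero atoms) in place of a group of 9 heavy atoms (7 carbon, 2 nitrogen; one five-membered aromatic ring with 2 hetero atoms, one six-membered non-aromatic ring with 1 hetero atom), on an aromatic carbon. In this assay compound 3 gives 550000 nM, and the step of an at least 1.8-fold lower number from compound 1 to compound 3 (0.25 log units; that floor lies within the scatter).

Compound 4 `CC(=O)N[C@@H]1CCC[C@H](C(=O)Nc2cc(-c3cnn4c3CC(C)(C)C4)c(Cl)cn2)C1` has not yet been measured. From compound 3 to compound 4 the change is chloro in place of fluoro on an aromatic carbon. Its place is ortho to a large group, whereas from compound 1 to compound 2 the place is ortho to a group of 9 heavy atoms; it is the same kind of change, on a different core.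

On the earlier step of an at least 3.2-fold lower number from compound 1 to compound 2 (0.50 log units; beyond the scatter), a step of similar size is expected from compound 3 to compound 4, a 3.1-fold lower number from compound 3 to compound 4 (0.49 log units; beyond the scatter). Compound 4 is therefore estimated at 180000 nM, with a range from 80000 nM to 400000 nM.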

Compound 4, solubility: 150000 nM
The estimate for compound 4 lay 1.2-fold (0.08 log units) above the measured number, within the range that was stated.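

In this assay, chloro in place of fluoro on an aromatic carbon gives a 3.7-fold lower number from compound 3 to compound 4 (0.56 log units; beyond the scatter), and the same direction appears on the core of compound 1 as an at least 3.2-fold lower number from compound 1 to compound 2 (0.50 log units; beyond the scatter), so the direction of this change carries across the two cores shown. Read among the chloro compounds, the core change gives a 2.1-fold lower number from compound 2 to compound 4 (0.32 log units; beyond the scatter), which is beyond the scatter. Compound 1 sits at a limit of the assay and not at a number, so the result does not show whether the step keeps its size from one core to the other: the limit of > 1000000 nM in this assay, at which 1 of the 4 values shown sits.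

The compounds shown leave open whether the direction holds on any further core, since only one pair of cores can be read here. They also leave open how other groups would behave in place of chloro or fluoro on that aromatic carbon, such as a nitrile or a methoxy group, or how an amine would behave in place of the acetyl amide.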